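Taking the Methoxy Group Away from Compound 2

A few compounds are considered here, and "the series" means these few. Any claim that something is new, unique, unknown or untested is made for them only; others in the source may bear on it.

Of the compounds shown here, two sharing one core have been measured in a functional assay on SW-620 cells (Homo sapiens) for cytotoxicity; on this read-out lower numbers stand for stronger inhibition of growth and higher numbers for weaker inhibition of growth. Compound 1 `COc1ccc(C2=C(c3ccc(SC)cc3)CC3CCCN3C2=O)cc1C` gives 500 nM, while compound 2 `COc1ccc(C2=C(c3ccc(SC)cc3)CC3CCCN3C2=O)cc1OC` gives 3000 nM, the higher of the two numbers. Going by the values given here, the one measured step between them is a 6.0-fold higher number from compound 1 to compound 2 (0.78 log units; beyond the scatter), with methoxy in place of methyl on an aromatic carbon. It is modest but lies beyond the scatter.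

Compound 3 `COc1ccc(C2=C(c3ccc(SC)cc3)CC3CCCN3C2=O)cc1` has not yet been measured. It differs from compound 2 by hydrogen in place of methoxy on an aromatic carbon. Among the compounds with values here, this is the same aromatic carbon that changes in the measured step, which is the only guide available. Within the data shown here, no measured compound carries hydrogen there, so the size of the change remains uncertain. Given a 6.0-fold higher number from compound 1 to compound 2 (0.78 log units; beyond the scatter), removing the methoxy group is expected to lower the number in this assay, by a modest step. The estimated step is a 3.0-fold lower number from compound 2 to compound 3 (0.48 log units; beyond the scatter). Compound 3 is expected at 1000 nM, with an estimated range of 300 nM to 4000 nM.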

Compound 3, concentration for 50% growth inhibition: 3000 nM
Compound 3: the middle estimate sits 3.0-fold (0.48 log units) below what was measured; the range from low to high includes it.
By their numbers in this assay, from the lowest: compound 1; then compounds 2 and 3 (each within the scatter of the next).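

At this aromatic carbon, ortho to a methoxy group, hydrogen in place of methoxy gives no change at the digits printed from compound 2 to compound 3 (within the scatter) in this assay, so the second methoxy group and a bare hydrogen cannot be told apart on this read-out. Hydrogen in place of methyl gives a 6.0-fold higher number from compound 1 to compound 3 (0.78 log units; beyond the scatter), which shows what the single earlier step could not: compound 1 with its methyl group stands apart from both of the others, rather than the methoxy group of compound 2 marking a departure from a hydrogen-bearing compound. Nothing available explains why methyl differs here from both methoxy and hydrogen.

Going by these compounds alone, with methyl as the only group at this carbon that gives a lower number, the three compounds leave open whether that result is particular to methyl or would also appear with an ethyl group, a chlorine atom or a trifluoromethyl group. They also leave open whether an amine or a hydroxyl group at the same carbon would give a number close to that of compound 1 or close to those of compound 2 and compound 3.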